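Phenyl to (furan-2-yl)methyl on the shared core

The source may report more compounds than this note shows. Statements on the series, on what has been measured and on what is new or still open speak of the compounds shown alone.

In a functional assay on MCF7 cells (Homo sapiens) for inhibition, read by CCK-8 assay, with a stated time of 48 h (a lower number here means a stronger inhibitor of growth, a higher number a weaker inhibitor of growth), compound 1 (`Cc1ccccc1Nc1nc(Nc2ccccn2)ncc1Cl`) gives 31400 nM as a measured number. Compound 2 (`Cc1ccccc1Nc1nc(Nc2cc(Cl)ccn2)ncc1Cl`) gives > 100000 nM and this is a limit of the assay, not a number. Compound 3 (`CN1CCN(c2ccc(Nc3ncc(Cl)c(Nc4ccccc4)n3)nc2)CC1`) gives 51800 nM and so lies within the scatter of compound 1 at 31400 nM in the same read-out.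

The next change leads to compound 4 (`CN1CCN(c2ccc(Nc3ncc(Cl)c(NCc4ccco4)n3)nc2)CC1`). It is (furan-2-yl)methyl in place of phenyl on a nitrogen on an aromatic ring, which also reads as anilino to ((furan-2-yl)methyl)amino.

The series holds one measured step, an at least 3.1-fold higher number from compound 1 to compound 2 (0.50 log units; beyond the scatter) for chloro in place of hydrogen on an aromatic carbon, and it ends at the limit of > 100000 nM in this assay, at which 1 of the 3 values shown sits, in the data. That step lies beyond the scatter, but it is a different change at a different place, so it gives no size for this replacement. Going by the values given here, no measured step covers the loss of phenyl. The expectation therefore rests on compound 3 at 51800 nM as the only anchor, with no shift beyond the scatter expected in this assay and no direction favoured. The estimated step is a 1.2-fold lower number from compound 3 to compound 4 (0.06 log units; within the scatter) and it is expected to stay small. For compound 4 the estimated value is 45000 nM (expected range 15000 nM to 100000 nM).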

Compound 4, concentration for 50% growth inhibition: 21300 nM
Compound 4: the middle estimate sits 2.1-fold (0.32 log units) above what was measured, within the range that was stated.
By their numbers in this assay, from the lowest: compounds 4, 1 and 3 (each within the scatter of the next, the first and the last beyond it). At a limit, above all of these: compound 2.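

In this assay, anilino to ((furan-2-yl)methyl)amino on the core of compound 3 gives a 2.4-fold lower number from compound 3 to compound 4 (0.39 log units; beyond the scatter), so phenyl is not needed on this nitrogen for the growth inhibition seen here, and compound 4 reads 21300 nM. Going by these compounds alone, this is the first measured step at this place, and it shows that a five-membered aromatic ring with 1 hetero atom, carried as (furan-2-yl)methyl, is accepted here; the only earlier step, chloro in place of hydrogen on an aromatic carbon, lies at a different place and gave no information on this one. No data shown here bear on why the number falls with this change.

The step changes the ring and adds a carbon link in one move, so the two contributions remain unseparated; a benzyl group or a (thiophen-2-yl)methyl group on the same nitrogen would be the direct test of each. Also open, on these data alone, is whether the same replacement gives a step of this size on compound 1, which differs from compound 3 elsewhere on the shared core.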